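Swapping the ring on the amide: compound 3 to compound 4

A few compounds are considered here, and "the series" means these few. Any claim that something is new, unique, unknown or untested is made for them only; others in the source may bear on it.

Measured so far:
- Compound 1, `O=C(c1ccc(Cl)cc1)N1CC(c2nc(-c3cccc(F)c3)no2)C1`, 2500 nM
- Compound 2, `O=C(C1CCCCC1)N1CC(c2nc(-c3cccc(F)c3)no2)C1`, 1000 nM
- Compound 3, `O=C(C1CCC(F)(F)CC1)N1CC(c2nc(-c3cccc(F)c3)no2)C1`, 520 nM

These three share one core and differ only in the group attached to the carbonyl carbon. In an assay on HEK293 cells for positive allosteric modulation of metabotropic glutamate receptor 5 (Homo sapiens), read by FLIPR (a higher number here means that more compound is needed for the effect, a lower number that less compound is needed), compound 3 gives the lowest number of the three. Its nearest neighbour is compound 2, and the step between them, a 1.9-fold lower number from compound 2 to compound 3 (0.28 log units; within the scatter), lies within the scatter, so the two cannot be ranked against each other. The step from the aromatic group is larger: a 4.8-fold lower number from compound 1 to compound 3 (0.68 log units; beyond the scatter), and a 2.5-fold lower number from compound 1 to compound 2 (0.40 log units; beyond the scatter) points the same way.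

Compound 4, `CC1CCCCC1C(=O)N1CC(c2nc(-c3cccc(F)c3)no2)C1`, is not yet measured. It differs from compound 3 in one place: 2-methylcyclohexyl in place of 4,4-difluorocyclohexyl on a carbonyl carbon. Among the measured compounds shown here, the two saturated rings seen so far, in compound 2 and compound 3, give numbers within the scatter of each other, and the methyl-bearing ring of compound 4 has no measured precedent here. The step from compound 3 to compound 4 is therefore expected to be small, most likely within the scatter, at a 1.5-fold higher number from compound 3 to compound 4 (0.19 log units; within the scatter), with no firm direction. For compound 4 the estimated value in this assay is 800 nM, within a range of 300 nM to 2500 nM.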

Compound 4, half-maximal effective concentration: 540 nM
Beside the measured number, compound 4's estimate is 1.5-fold (0.17 log units) above it, within the range that was stated.
By their numbers in this assay, from the lowest: compounds 3, 4 and 2 (each within the scatter of the next); then compound 1.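

In this assay, methyl in place of hydrogen on a saturated ring carbon gives a 1.9-fold lower number from compound 2 to compound 4 (0.27 log units; within the scatter), and replacing 4,4-difluorocyclohexyl with 2-methylcyclohexyl gives a 1.0-fold higher number from compound 3 to compound 4 (0.02 log units; within the scatter), so neither step separates the compounds and the plain, difluorinated and methylated six-membered carbon rings cannot be ranked against one another at this position on the carbonyl carbon. The advantage of a saturated ring over 4-chlorophenyl now rests on a third example, a 4.6-fold lower number from compound 1 to compound 4 (0.67 log units; beyond the scatter), and no compound shown goes against this pattern, although it remains a modest step. Nothing measured here explains why these rings behave alike or why they differ from 4-chlorophenyl.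

Every saturated group shown is a six-membered carbon ring, so it remains open whether a smaller cyclopropyl ring, an open tert-butyl chain or a ring carrying an amine or a carboxylic acid would fit this series. Plain phenyl is also absent, which leaves open whether the gap to compound 1 follows the aromatic ring itself or its chlorine.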